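The source may report more compounds than this note shows. Statements on the series, on what has been measured and on what is new or still open speak of the compounds shown alone.

Measured compounds:
- compound 1 `COc1cccc(S(=O)(=O)/C=C/c2ncccc2Cl)c1`: 22%
- compound 2 `COc1ccccc1S(=O)(=O)/C=C/c1cccnc1`: 97%
- compound 3 `COc1ccccc1S(=O)(=O)/C=C/c1cccnc1OC`: "not determined" (no result reported)

These compounds were tested in an ADME assay on microsomes from liver (Homo sapiens) for metabolic stability, read by LC-MS, using NADPH, with stated times of 5 min and 30 min, tested at 1 uM; a higher number here means that more of the compound is left, a lower number that less of the compound is left. Compound 3 has no number to stand on, as its entry reads "not determined" (no result reported), so it cannot be placed relative to the other two. Compound 4 `COc1ccccc1S(=O)(=O)/C=C/c1cccnc1Cl` has not yet been measured. The structural change is chloro in place of methoxy on an aromatic carbon: chloro takes the place of methoxy on an aromatic carbon, next to the ring nitrogen and ortho to a large group.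

With no result for compound 3, the size of this step cannot be judged directly, and no direction can be expected from it. For the measured compounds named here, the only guide is the wide spread of the two measured compounds. Compound 2 gives 97%, while compound 1, which also carries a chloro group, gives 22%. These two differ in more than one place, so neither value transfers cleanly to compound 4. A result between them seems most likely, closer to compound 2, which shares the methoxy-bearing portion of compound 4. The uncertainty stays wide. For compound 4 the expected value in this assay is 68%, with an estimated range from 35% to 95%.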

Compound 4, percent of the compound remaining: 77%
Compound 4: the middle estimate sits 9 percentage points below what was measured, within the range that was stated.
By their numbers in this assay, from the lowest: compound 1; then compound 4; then compound 2.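

The one-place change of hydrogen to chloro on an aromatic carbon, next to the ring nitrogen and ortho to a large group, gives in this assay a number 20 percentage points lower from compound 2 to compound 4 (beyond the scatter). For the compounds shown here, this is the first comparison in the set that isolates a single change, and it shows that this position is not indifferent to what sits on it, although compound 4 still keeps most of its material at 77%. The compounds shown come with no measurement that explains the drop, so the result describes what happened but not the reason for it.

Compound 3 has no result, so the steps that would link its methoxy group to hydrogen or to chloro cannot be read, and compound 1 differs from the others in more than one place and cannot fill that gap. On these data alone, it also remains open how this position would respond to a fluoro group, a nitrile, an amine or a carboxylic acid, and whether the response seen with chloro would hold for any of them.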